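The compounds below may be only part of what the source reports. "The series", "measured", "known", "first", "only" and "open" are said of these compounds alone.

Measured so far:
Compound 1 `CCSC(=S)SCC(=O)c1cccc(C(=O)Nc2ccccc2)c1`: 2400 nM
Compound 2 `CCOC(=S)SCC(=O)c1ccc(NC(C)=O)cc1`: 3610 nM
Compound 3 `CCSC(=S)SCC(=O)c1ccc(C(=O)Nc2ccccc2)cc1`: 25800 nM

In a functional assay on HeLa cells (Homo sapiens) for cytotoxicity, read by resazurin assay, with a stated time of 72 h (a higher number here means a weaker inhibitor, a lower number a stronger inhibitor), compound 2 gives 3610 nM. That lies within the scatter of compound 1 and well below compound 3, so compound 2 belongs with the stronger inhibitors of this small set.

Compound 4 `CCOC(=S)SCC(=O)c1ccc(OC)cc1` has methoxy in place of acetamido on an aromatic carbon. Within the data shown here, no measured pair shows this change alone, so the data offer no direct guide to its size. The expectation in this assay is therefore no step beyond the scatter, with neither direction favoured. The expected change is an estimated 1.1-fold higher number from compound 2 to compound 4 (0.04 log units; within the scatter). The range stays wide, since compound 1 at 2400 nM and compound 3 at 25800 nM lie far apart. For compound 4 the estimated value is 4000 nM, with an expected range of 1500 nM to 11000 nM.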

Compound 4, half-maximal inhibitory concentration: 4640 nM
Beside the measured number, compound 4's estimate is 1.2-fold (0.06 log units) below it; the range from low to high includes it.
By their numbers in this assay, from the lowest: compounds 1, 2 and 4 (each within the scatter of the next); then compound 3.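

In this assay, methoxy in place of acetamido on this aromatic carbon gives a 1.3-fold higher number from compound 2 to compound 4 (0.11 log units; within the scatter). This first direct test of the position shows that, for this pair, the group can lose the hydrogen-bond donor of acetamido and still leave the two compounds indistinguishable in this cell assay. No supporting measurement explains this result.

Still open, going by these compounds, is whether this tolerance extends to a quite different group at the same place, such as an amine or a carboxylic acid. One pair cannot show how far it reaches.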